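Three thioethers at the assay limit, a fourth awaited

A few compounds are considered here, and "the series" means these few. Any claim that something is new, unique, unknown or untested is made for them only; others in the source may bear on it.

Of the compounds shown here, three have been measured in a functional assay on MCF7 cells (Homo sapiens) for cytotoxicity, read by MTT assay, with a stated time of 72 h; on this read-out higher numbers stand for weaker inhibition and lower numbers for stronger inhibition. Each of the three values is a limit of the assay rather than a number.

Compound 1, `Cc1nnc(SCc2cc(=O)c3ccccc3o2)s1`, gives > 25000 nM.
Compound 2, `Nc1nnc(SCc2cc(=O)c3ccccc3o2)s1`, gives > 25000 nM.
Compound 3, `Nc1nnc(SCc2cc(=O)c3cc(Cl)ccc3o2)s1`, gives > 25000 nM.

Compound 3 therefore stands at the limit, as do the other two, and this is all that can be said of its place: the limit of > 25000 nM in this assay, at which 3 of the 3 values shown sit. Among the compounds with values here, the step from compound 2 to compound 3 could not be read, a step that the two limits leave unreadable from compound 2 to compound 3, and neither could the one from compound 1 to compound 2, a step that the two limits leave unreadable from compound 1 to compound 2.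

Compound 4, `Cc1nnc(SCc2cc(=O)c3cc(Cl)ccc3o2)s1`, is the next compound to be measured. It differs from compound 3 in one place: methyl in place of amino on an aromatic carbon. Within the data shown here, this is the same exchange as the one from compound 1 to compound 2, only run in the opposite direction, and that exchange left no readable step. Compound 1, which carries the same methyl group on its five-membered ring, gives > 25000 nM as a limit.

Nothing in the measured steps points to a direction, so no step beyond the scatter is expected. Compound 4 is expected to give 40000 nM, with a range from 15000 nM to 120000 nM, most likely again as a limit. The expected step is a step that the limit leaves unreadable from compound 3 to compound 4.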

Compound 4, half-maximal inhibitory concentration: > 25000 nM
Compound 4 gave a limit, no number (the forecaster's own chance of this, stated with the estimate: 80%); the middle value lies beyond the limit too.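

Compound 4 also gives only a limit and no number, and neither step to it, from compound 3 or from compound 1, can be read: the limit of > 25000 nM in this assay, at which 4 of the 4 values shown sit. The compounds shown leave open whether exchanging methyl and amino, or hydrogen and chloro, changes the read-out at all.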